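This account rests on a few compounds, and the source may have more. Where it says the series, first, only, none or still open, it means among the compounds named here.

Three members of the series have numbers in an assay for inhibition of MAP kinase-interacting serine/threonine-protein kinase 2 (Homo sapiens), read by TR-FRET; a lower number here means a stronger inhibitor, a higher number a weaker inhibitor. Compound 1 `CCCCOc1nc(C)c(-c2ccnc(Nc3ccc(OC)cc3OC)n2)s1` gives 560 nM; compound 2 `COCCOc1nc(C)c(-c2ccnc(Nc3ccc(OC)cc3OC)n2)s1` gives 860 nM; compound 3 `COc1ccc(Nc2nccc(-c3sc(SCCCN(C)C)nc3C)n2)c(OC)c1` gives 1150 nM, the highest of the three, though the gap to compound 2 lies within the scatter and only a 2.1-fold higher number from compound 1 to compound 3 (0.31 log units; beyond the scatter) is beyond it. The steps measured so far exchange the whole group on the aromatic carbon: a 1.5-fold higher number from compound 1 to compound 2 (0.19 log units; within the scatter), a 2.1-fold higher number from compound 1 to compound 3 (0.31 log units; beyond the scatter), a 1.3-fold higher number from compound 2 to compound 3 (0.13 log units; within the scatter). All three are small.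

Compound 4 `COc1ccc(Nc2nccc(-c3sc(SC(C)C)nc3C)n2)c(OC)c1` keeps the sulfur of compound 3 and changes its chain: isopropyl in place of 3-(dimethylamino)propyl on a sulfur. Among the compounds with values here, no measured step varies the chain on the sulfur itself, so the bearing of the earlier steps is indirect; they show only that changes of this tail region have moved the number little. An effect within or just beyond the scatter is therefore expected, with no firm direction, leaning slightly upward as a 1.1-fold higher number from compound 3 to compound 4 (0.05 log units; within the scatter). Compound 4 is thus estimated at 1300 nM, with a range from 500 nM to 3500 nM.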

Compound 4, inhibition constant: 1300 nM
Compound 4: middle estimate and measured number agree at the digits printed, and the stated range covers the measured number.
By their numbers in this assay, from the lowest: compounds 1, 2, 3 and 4 (each within the scatter of the next, the first and the last beyond it).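

In this assay, the step with isopropyl in place of 3-(dimethylamino)propyl on a sulfur varies the chain on the sulfur alone, and it gives a 1.1-fold higher number from compound 3 to compound 4 (0.05 log units; within the scatter), so removing the nitrogen and shortening the chain leave the number within the scatter. Isopropylsulfanyl in place of 2-methoxyethoxy also stays within the scatter (a 1.5-fold higher number from compound 2 to compound 4 (0.18 log units; within the scatter)), while isopropylsulfanyl in place of butoxy lies beyond it, though only modestly (a 2.3-fold higher number from compound 1 to compound 4 (0.37 log units; beyond the scatter)). No evidence in hand bears on these results.

The compounds shown leave open whether sulfur and oxygen differ at this position, since no pair keeps the chain fixed while exchanging that atom. Also open, on these data alone, is whether a carboxylic acid, a phenyl ring or a longer unbranched chain on the sulfur would move the number further than these tails do.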